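The compounds below may be only part of what the source reports. "The series", "measured", "known", "first", "only" and "open" are said of these compounds alone.

Working notes on the series. In a functional assay on Jurkat cells (Homo sapiens) for cytotoxicity, read by MTT assay, with a stated time of 24 h (on this read-out lower numbers stand for an effect already at smaller amounts and higher numbers for an effect only at larger amounts of compound), compound 1 `CCOC(=O)c1cc(C#Cc2ccc(N)cc2)c2cc(OC)ccc2n1` gives 61000 nM while compound 2 `CCOC(=O)c1cc([Se]c2ccccc2)c2cc(Cl)ccc2n1` gives 53000 nM and compound 3 `CCOC(=O)c1cc([Te]c2ccccc2)c2cc(OC)ccc2n1` gives 77400 nM as its number. Compound 2 stands within the scatter of both compound 1 and compound 3, so these three compounds share one narrow band. Within the data shown here, no two of them differ in a single place, so no measured step is available to size a single change.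

Compound 4 `CCOC(=O)c1cc([Se]c2ccccc2)c2ccccc2n1` follows from compound 2 by hydrogen in place of chloro on an aromatic carbon, counted as hydrogen in place of chloro on an aromatic carbon and not yet measured. No shift beyond the scatter is expected in this assay and no direction is favoured. This expectation rests only on the narrow band around compound 2 at 53000 nM and on the absence of any measured step. The expected change is a 1.0-fold higher number from compound 2 to compound 4 (0.02 log units; within the scatter) and this estimate lies within the scatter. The estimate for compound 4 is 55000 nM with 28000 nM to 105000 nM as its expected range.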

Compound 4, half-maximal effective concentration: 98200 nM
The estimate for compound 4 lay 1.8-fold (0.25 log units) below the measured number, and the stated range covers the measured number.
By their numbers in this assay, from the lowest: compounds 2, 1, 3 and 4 (each within the scatter of the next).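

In this assay the series now has its first measured step at a single place, a 1.9-fold higher number from compound 2 to compound 4 (0.27 log units; within the scatter), so hydrogen in place of chloro on this aromatic carbon is not separated from the usual scatter of repeated measurements. For this pair, then, the chloro group is not shown to matter at this position, although a single step cannot settle that for the series as a whole. Nothing measured bears on why the pair reads as it does.

The compounds shown leave open whether another group on this aromatic carbon, such as trifluoromethyl or a nitrile, would move the number beyond the scatter. They also leave open what a carboxylic acid in place of the ethyl ester would do on the core of compound 4.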